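Methoxyphenyl Exchanged for Thiophenyl on a Fused Core

This account rests on a few compounds, and the source may have more. Where it says the series, first, only, none or still open, it means among the compounds named here.

Measured so far:
Compound 1 `Brc1cn2ccnc2c(-c2ccc3ncn(C4CCCCC4)c3c2)n1` gives 13.4% in a functional assay on SK-MEL-5 cells (Homo sapiens) for inhibition, read by sulforhodamine B assay, with a stated time of 48 h, tested at 10 uM; on this read-out higher numbers stand for more inhibition at the one concentration tested (going by the name of the read-out) and lower numbers for less inhibition.
Compound 2 `COc1ccc(-c2cn3ccnc3c(-c3ccc4ncn(C5CCCCC5)c4c3)n2)cc1` gives 92.3% in this assay.

Compound 2 holds the higher of the two numbers. For the measured compounds named here, the one measured step, a number 78.9 percentage points higher from compound 1 to compound 2 (beyond the scatter), is large and lies beyond the scatter, so the two measured compounds are far apart.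

Compound 3 `c1cn2cc(-c3ccsc3)nc(-c3ccc4ncn(C5CCCCC5)c4c3)c2n1` has not yet been measured in this assay. It differs from compound 2 by thiophen-3-yl in place of 4-methoxyphenyl on an aromatic carbon.

Going by the values given here, only one measured step exists, and it bears on this change just indirectly: a number 78.9 percentage points higher from compound 1 to compound 2 (beyond the scatter) shows that an aromatic ring in place of bromo at this position raised inhibition greatly. Compound 3 keeps an aromatic ring there, though a five-membered one with one hetero atom rather than the six-membered carbon ring. Among the compounds with values here, no measured pair compares two different aromatic rings at this position, so the size of the change is uncertain. A moderate drop is expected, with the estimated step of a number 22.3 percentage points lower from compound 2 to compound 3 (beyond the scatter). Compound 3 is therefore expected to give about 70% in this assay, with an estimated range from 35% to 95%.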

Compound 3, a percentage reported as inhibition, at one concentration (the size of the read-out at that concentration, not a potency): 25%
Compound 3: middle estimate off by 45 percentage points, on the high side; measured number outside the range, below it.
By their numbers in this assay, from the lowest: compound 1; then compound 3; then compound 2.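

In this assay an aromatic ring at this position is clearly not enough on its own, since thiophen-3-yl in place of 4-methoxyphenyl gives a number 67.3 percentage points lower from compound 2 to compound 3 (beyond the scatter) and the two rings are therefore far from interchangeable here. Thiophen-3-yl in place of bromo gives only a number 11.6 percentage points higher from compound 1 to compound 3 (beyond the scatter) and so keeps just a small part of the gain seen with 4-methoxyphenyl, which gives a number 78.9 percentage points higher from compound 1 to compound 2 (beyond the scatter) for the same starting point. The exchange changes the ring size, brings in a sulfur atom and removes the methoxy group all at once, and nothing available here explains the drop or separates these three changes.

The compounds shown leave open whether the high number of compound 2 depends on the methoxy group or on the six-membered ring itself, a question that a plain phenyl ring at the same place would help to settle. As far as these compounds go, how a 4-aminophenyl group, a pyridine ring or a thiophen-2-yl group would fall in this range also remains open.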